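The compounds below may be only part of what the source reports. "The series", "measured", "known", "first", "only" and "open" are said of these compounds alone.

Of the compounds shown here, two from this series have been tested in a functional assay on FaDu cells (Homo sapiens) for cytotoxicity, read by MTT assay, with a stated time of 72 h; a lower number here means that less compound is tolerated, a higher number that more compound is tolerated. Compound 1 `COCC(C)n1cc(C(=O)C(=O)Nc2ccc(OC)nc2)c2ccccc21` gives the lower of the two numbers: in this assay compound 1 gives 12 nM. Compound 2 `COCCn1cc(C(=O)C(=O)Nc2ccnc(OC)c2)c2ccccc21` differs from compound 1 at several positions at once. In this assay compound 2 gives 235 nM, a gap that lies well beyond the ordinary scatter of such measurements. Because the two compounds differ at several positions, their values alone cannot say which change accounts for the gap.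

Compound 3 `COCC(C)(C)n1cc(C(=O)C(=O)Nc2ccc(OC)nc2)c2ccccc21` has not yet been measured. It is built from compound 1 by a single change, (methyl in place of hydrogen on a saturated chain carbon bound to an aromatic nitrogen and two saturated chain carbons), so that the chain carbon bound to the aromatic nitrogen now carries two methyl groups instead of one. For the measured compounds named here, no measured pair in this set shows the effect of this particular change, so there is no step to lean on. The change is small, and the expectation is a step from compound 1 to compound 3 of a 2.1-fold higher number from compound 1 to compound 3 (0.32 log units; beyond the scatter), likely within or only slightly beyond the scatter. Compound 3 is therefore estimated at 25 nM in this assay, with a range from 6 nM to 100 nM.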

Compound 3, concentration lethal to 50% of the cells: 137 nM
For compound 3 the middle estimate is 5.5-fold (0.74 log units) below the measured one, and the stated range ends below it.
By their numbers in this assay, from the lowest: compound 1; then compounds 3 and 2 (each within the scatter of the next).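

In this assay, adding one methyl gives a large step, an 11-fold higher number from compound 1 to compound 3 (1.06 log units; beyond the scatter), so a higher number means that more compound is tolerated after the change. Compound 1 and compound 2 differ at several positions and could not separate the effect of any one change, but compound 1 and compound 3 differ in one place only. The whole gap therefore belongs to the change from 1-(methoxymethyl)ethyl to 1-(methoxymethyl)-1-methylethyl, which shows that the outcome in this assay is sensitive to a single added carbon on the saturated chain carbon bound to the aromatic nitrogen. No measurement available here explains how the added methyl produces this step.

The compounds shown leave open whether an ethyl group in place of the added methyl, or a longer chain at the same carbon, would give a step of similar size. They also leave open whether the added methyl would have the same effect in a compound carrying an amine or a carboxylic acid elsewhere on the shared core.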